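This account rests on a few compounds, and the source may have more. Where it says the series, first, only, none or still open, it means among the compounds named here.

In a functional assay on MCF7 cells (Homo sapiens) for cytotoxicity, read by MTT assay, with a stated time of 72 h (on this read-out lower numbers stand for stronger inhibition and higher numbers for weaker inhibition), compound 1 `COc1cc(/C=C/C(=O)Nc2cc3c(Nc4ccc(F)c(Cl)c4)ncnc3cc2O[C@H]2CCOC2)cc(OC)c1OC` gives 28400 nM, compound 2 `COc1cc(/C=C/C(=O)Nc2cc3c(Nc4ccc(F)c(Cl)c4)ncnc3cc2OC)cc(OC)c1` gives 38500 nM, and compound 3 `COc1cc(/C=C/C(=O)Nc2cc3c(Nc4ccc(F)c(Cl)c4)ncnc3cc2O[C@H]2CCOC2)cc(OC)c1` gives 30300 nM. Compound 3 holds the second highest of these three numbers, yet each gap to the others is within the scatter: a 1.1-fold higher number from compound 1 to compound 3 (0.03 log units; within the scatter), and a 1.3-fold lower number from compound 2 to compound 3 (0.10 log units; within the scatter). Compound 4 `O=C(/C=C/c1ccc(F)cc1Cl)Nc1cc2c(Nc3ccc(F)c(Cl)c3)ncnc2cc1O[C@H]1CCOC1` carries a single change from compound 3: 2-chloro-4-fluorophenyl in place of 3,5-dimethoxyphenyl on a double-bonded chain carbon bound to a double-bonded chain carbon. Going by the values given here, no measured step touches this part of the shared core; the two steps seen concern other parts and both fell within the scatter, so nothing here points in either direction. The expected step is therefore a 1.0-fold lower number from compound 3 to compound 4 (0.00 log units; within the scatter), not beyond the scatter. Compound 4 is estimated to give 30000 nM, with a range from 9000 nM to 100000 nM.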

Compound 4, half-maximal inhibitory concentration: 26200 nM
Compound 4: middle estimate off by 1.1-fold (0.06 log units), on the high side; the measured number falls inside the stated range.
By their numbers in this assay, from the lowest: compounds 4, 1, 3 and 2 (each within the scatter of the next).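

In this assay, putting 2-chloro-4-fluorophenyl in place of 3,5-dimethoxyphenyl on the double-bonded chain carbon leaves the number within the scatter (a 1.2-fold lower number from compound 3 to compound 4 (0.06 log units; within the scatter)), and the same holds for replacing 3,4,5-trimethoxyphenyl (a 1.1-fold lower number from compound 1 to compound 4 (0.04 log units; within the scatter)). The earlier steps shown here never touched this position, and it now tolerates a ring with chlorine and fluorine instead of methoxy groups without a change beyond the scatter. Nothing available explains this result.

On these data alone, whether an amine or a carboxylic acid on this ring would move the number beyond the scatter remains open. So does the separate contribution of the chlorine and the fluorine.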